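The compounds below may be only part of what the source reports. "The series", "measured", "known", "first", "only" and "open" are said of these compounds alone.

Two compounds share one core and differ only in what hangs from the side chain. Compound 1 `COc1nc(C)c(Nc2nc(Cl)cn([C@H](COC(=O)Nc3cccc(C#N)c3)C3CC3)c2=O)cc1C` gives 1.3 nM in an assay on frontal cortex for displacement of a labelled ligand from corticotropin-releasing factor receptor 1 (Rattus norvegicus), with a stated time of 2 h; on this read-out lower numbers stand for stronger inhibition and higher numbers for weaker inhibition. Compound 2 `CCCCNC(=O)OC[C@H](C1CC1)n1cc(Cl)nc(Nc2cc(C)c(OC)nc2C)c1=O` gives 4.7 nM in this assay, and the change between them is a 3.6-fold higher number from compound 1 to compound 2 (0.56 log units; beyond the scatter). For the measured compounds named here, on these two numbers compound 2 stands highest, with compound 1 as its only neighbour.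

Compound 3 `COc1nc(C)c(Nc2nc(Cl)cn([C@H](COc3ccccn3)C3CC3)c2=O)cc1C` is the next step: pyridin-2-yl in place of butylcarbamoyl on an oxygen on a saturated carbon. Going by the values given here, the one measured step touched only the group on the far end of the carbamate and left the carbamate itself in place, so it does not directly bear on removing the whole butylcarbamoyl group for a pyridin-2-yl. With no closer guide, no step beyond the scatter is expected in either direction, and the estimate is held loose. Compound 3 is expected to give about 5 nM, between 1.5 nM and 20 nM, which means a 1.1-fold higher number from compound 2 to compound 3 (0.03 log units; within the scatter).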

Compound 3, half-maximal inhibitory concentration: 1.2 nM
Estimate against measurement, compound 3: 4.2-fold (0.62 log units) above; measured number outside the range, below it.
By their numbers in this assay, from the lowest: compounds 3 and 1 (each within the scatter of the next); then compound 2.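

Butylcarbamoyl is not needed at this oxygen on a saturated carbon: replacing it with pyridin-2-yl gives a 3.9-fold lower number from compound 2 to compound 3 (0.59 log units; beyond the scatter) in this assay, so the carbamate linkage can be removed altogether without losing binding. The earlier pair only varied the far end of the carbamate, whereas this change removes the linkage and its amide hydrogen. Compared with the 3-cyanophenyl carbamate, the same swap gives a 1.1-fold lower number from compound 1 to compound 3 (0.03 log units; within the scatter), so these two compounds cannot be told apart, and among these three compounds only the one with the butyl chain stands apart, with the higher number.

No measurement here explains why these numbers differ. The compounds shown leave open whether the ring nitrogen of pyridin-2-yl matters, which phenyl or pyridin-3-yl on the same oxygen could test, and whether a simple butyl group on that oxygen would behave like the butyl carbamate.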